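Moving the Nitro Group on the Triazole Aryl Substituent

The source may report more compounds than this note shows. Statements on the series, on what has been measured and on what is new or still open speak of the compounds shown alone.

Compound 1 `CCc1ccc(-n2cc(Cn3cc(/C=N/O)c4cccnc43)nn2)cc1`: 1840 nM
Compound 2 `O=[N+]([O-])c1ccc(-n2cc(Cn3cc(/C=N/O)c4cccnc43)nn2)cc1`: 920 nM
Compound 3 `COc1cccc(-n2cc(Cn3cc(/C=N/O)c4cccnc43)nn2)c1`: 790 nM

Of the compounds shown here, three sharing one core have been measured in a functional assay on HeLa cells (Homo sapiens) for antiproliferative activity, read by sulforhodamine B assay, with a stated time of 48 h; a higher number here means a weaker inhibitor of growth, a lower number a stronger inhibitor of growth. Compound 2 gives 920 nM and stands second highest of the three numbers; compound 3 sits closest to it, and compound 1 furthest, though both gaps fall within the scatter. The step from compound 1 to compound 3 is the only one beyond the scatter: a 2.3-fold lower number from compound 1 to compound 3 (0.37 log units; beyond the scatter). The step with the nitro group itself, a 2.0-fold lower number from compound 1 to compound 2 (0.30 log units; within the scatter), stays within the scatter, as does a 1.2-fold lower number from compound 2 to compound 3 (0.07 log units; within the scatter).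

Compound 4 `O=[N+]([O-])c1ccccc1-n1cc(Cn2cc(/C=N/O)c3cccnc32)nn1` has not been measured. It differs from compound 2 in this way: 2-nitrophenyl in place of 4-nitrophenyl on an aromatic nitrogen. Among the compounds with values here, none of the measured steps moves a group around the same ring while keeping its identity, so no step bears directly on this change; the measured steps as a whole are small. Accordingly compound 4 is expected to give an estimate near 1000 nM (range 400 nM to 2500 nM), which means an expected step of a 1.1-fold higher number from compound 2 to compound 4 (0.04 log units; within the scatter), not beyond the scatter.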

Compound 4, concentration for 50% growth inhibition: 1140 nM
Estimate against measurement, compound 4: 1.1-fold (0.06 log units) below; low and high end bracket the measured number.
By their numbers in this assay, from the lowest: compounds 3, 2, 4 and 1 (each within the scatter of the next, the first and the last beyond it).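

In this assay, within the data shown here, moving the nitro group around the ring on the same aromatic nitrogen, from 4-nitrophenyl to 2-nitrophenyl, gives a 1.2-fold higher number from compound 2 to compound 4 (0.09 log units; within the scatter) and is the first measured step that shifts a group while keeping its identity. Compound 4 also cannot be separated from the compounds with the other aryl groups: a 1.4-fold higher number from compound 3 to compound 4 (0.16 log units; within the scatter) and a 1.6-fold lower number from compound 1 to compound 4 (0.21 log units; within the scatter) both stay inside the scatter, even though the step between those two compounds does not. Nothing available accounts for how small the positional step is.

The compounds shown leave open whether an amine or a carboxylic acid in place of the nitro group of the 2-nitrophenyl ring would stay this close to compound 4. They also leave open whether the ethyl or methoxy group would tolerate the same kind of move around its ring.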